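The source may hold more compounds than are shown below. What is called first, only, known or untested is meant among the compounds shown, and "the series" means these compounds.

For the measured compounds named here, only two compounds have numbers so far in a functional assay on MDA-MB-231 cells (Homo sapiens) for antiproliferative activity, read by MTT assay, with a stated time of 48 h (on this read-out lower numbers stand for stronger inhibition and higher numbers for weaker inhibition), of this small series. Compound 1 `O=C(/C=C/c1ccccc1)Nc1cc2c(Nc3ccc(F)c(Cl)c3)ncnc2s1` gives 7600 nM and so holds the higher of the two values. Compound 2 `O=C(/C=C/c1ccccc1)Nc1cc2ncnc(Nc3ccc(F)c(Cl)c3)c2s1` comes in lower at 2100 nM and the gap lies beyond the scatter, which makes compound 1 the weaker of the pair.

Compound 3 `O=C(/C=C/c1ccccc1)Nc1cc2c(Nc3cc(Cl)cc(Cl)c3)ncnc2s1` has not yet been measured. It differs from compound 1 in one place, with 3,5-dichlorophenyl in place of 3-chloro-4-fluorophenyl on a nitrogen on an aromatic ring. The rest of the structure stays the same.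

Going by the values given here, no measured pair here shows what a change at this position does, so the expectation rests on the structural change alone. One chlorine stays in the group, and the fluorine gives way to a second chlorine. No step beyond the scatter is expected in this assay, and the direction is uncertain. The estimated 1.3-fold lower number from compound 1 to compound 3 (0.10 log units; within the scatter) is accordingly small. For compound 3 the expected value is 6000 nM within an estimated range of 2500 nM to 15000 nM for repeated measurements.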

Compound 3, half-maximal inhibitory concentration: 11500 nM
Beside the measured number, compound 3's estimate is 1.9-fold (0.28 log units) below it; low and high end bracket the measured number.
By their numbers in this assay, from the lowest: compound 2; then compounds 1 and 3 (each within the scatter of the next).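

For the compounds shown here, this is the first step that can be read at this position: in this assay, 3,5-dichlorophenyl in place of 3-chloro-4-fluorophenyl on a nitrogen on an aromatic ring gives a 1.5-fold higher number from compound 1 to compound 3 (0.18 log units; within the scatter) on the shared core. The exchange removes the fluorine and brings in a second chlorine, while the group keeps its 8 heavy atoms and its single six-membered aromatic ring, and on this read-out compound 1 and compound 3 cannot be told apart. No measurement among these data bears on the result or offers an explanation for it.

Going by these compounds alone, whether the same exchange would also stay within the scatter on the core of compound 2 remains open, since only one step at this position can be read and it belongs to the core of compound 1. Also open, from the compounds shown here alone, is how this position responds to groups of other kinds on the nitrogen, such as a phenyl ring carrying a methoxy group or a carboxylic acid, or a saturated amine such as morpholine in place of the substituted phenyl ring.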